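A few compounds are considered here, and "the series" means these few. Any claim that something is new, unique, unknown or untested is made for them only; others in the source may bear on it.

Measured in a functional assay on BaF3 cells (Mus musculus) for inhibition, read by CCK-8 assay, with a stated time of 72 h; a higher number here means a weaker inhibitor of growth, a lower number a stronger inhibitor of growth:
Compound 1 `CNc1cc(Oc2ccc(NC(=O)Nc3ccc(C)c(C(F)(F)F)c3)cc2)ncn1`: > 10000 nM (a limit)
Compound 2 `CC(=O)Nc1cc(Oc2ccc(NC(=O)Nc3ccc(C)c(C(F)(F)F)c3)cc2)ncn1`: 3230 nM
Compound 3 `Cc1ccc(NC(=O)Nc2ccc(Oc3cc(N)ncn3)cc2)cc1C(F)(F)F`: > 10000 nM (a limit)

Compound 3 gives only a limit, > 10000 nM. Most of the series stands on that boundary: the limit of > 10000 nM in this assay, at which 2 of the 3 values shown sit.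

The change to compound 4 `Cc1ccc(NC(=O)Nc2ccc(Oc3cc(N4CCNC[C@H]4C)ncn3)cc2)cc1C(F)(F)F` is 2-methylpiperazin-1-yl in place of amino on an aromatic carbon. The nearest evidence comes from changes on the nitrogen of that amino group. Acetyl in place of methyl gave an at least 3.0-fold lower number from compound 1 to compound 2 (0.49 log units; beyond the scatter), and hydrogen in place of acetyl gave an at least 3.0-fold higher number from compound 2 to compound 3 (0.49 log units; beyond the scatter). Hydrogen in place of methyl gave a step that the two limits leave unreadable from compound 1 to compound 3. Only the acetyl of compound 2 has produced a number, and the methyl of compound 1 goes against any general gain from substitution there. None of these steps brings in a ring, so they guide the estimate only loosely. A modest move towards a lower number is expected, and another limit remains quite possible. The expected change is an at least 2.5-fold lower number from compound 3 to compound 4 (0.39 log units; beyond the scatter). Compound 4 is estimated at 4000 nM, with an expected range of 800 nM to 20000 nM.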

Compound 4, concentration for 50% growth inhibition: 9670 nM
Beside the measured number, compound 4's estimate is 2.4-fold (0.38 log units) below it, and the stated range covers the measured number.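

In this assay, among the compounds shown here, the 2-methylpiperazin-1-yl group of compound 4 puts a non-aromatic ring on this aromatic carbon for the first time, and it brings no firm gain over the smaller nitrogen groups, with an at least 1.0-fold lower number from compound 3 to compound 4 (0.01 log units; that floor lies within the scatter) and an at least 1.0-fold lower number from compound 1 to compound 4 (0.01 log units; that floor lies within the scatter). The same ring clearly falls short of the acetamido group, with a 3.0-fold higher number from compound 2 to compound 4 (0.48 log units; beyond the scatter), so compound 2 remains the strongest of the four. Compound 1 and compound 3 each give only a limit and not a number: the limit of > 10000 nM in this assay, at which 2 of the 4 values shown sit.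

Going by these compounds, it remains open whether a plain piperazine, without the methyl group and its defined stereocentre, would behave any differently from compound 4. On these data alone, it is also open whether a longer amide such as propionamido would go beyond the acetamido group of compound 2.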